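The compounds below may be only part of what the source reports. "The series", "measured", "known", "first", "only" and "open" are said of these compounds alone.

Measured so far:
compound 1, `CCOC(=O)/C(C#N)=C(/Nc1ccc([N+](=O)[O-])cc1)N[C@H](C)c1ccccc1`, 23.6%
compound 2, `CCOC(=O)/C(C#N)=C(/NNC(=O)c1cc(OC)c(OC)c(OC)c1)N[C@@H](C)c1ccccc1`, 29.4%

Both numbers come from a functional assay on A-431 cells (Homo sapiens) for antiproliferative activity, read by MTT assay, with a stated time of 72 h, tested at 5 uM; on this read-out higher numbers stand for more inhibition at the one concentration tested (going by the name of the read-out) and lower numbers for less inhibition. In this assay, going by the values given here, compound 1 gives 23.6% and compound 2 gives 29.4%; the gap between these two numbers lies within the scatter, so neither can be set above the other, and compound 1 stands level with the only other measured compound. Compound 1 and compound 2 differ from each other in several places at once, so no single step can be read from the pair.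

Compound 3, `CCOC(=O)/C(C#N)=C(/Nc1ccc(C(F)(F)F)cc1)N[C@H](C)c1ccccc1`, is not yet measured. It differs from compound 1 in one place: trifluoromethyl in place of nitro on an aromatic carbon. Among the compounds with values here, no step between measured compounds bears on this change, and nothing in the two numbers at hand speaks for a large shift in either direction. The expected step in this assay is therefore about none beyond the scatter, a number 1.6 percentage points lower from compound 1 to compound 3 (within the scatter). For compound 3 the estimated inhibition in this assay is 22%, with an expected range from 8% to 38%.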

Compound 3, a percentage reported as inhibition, at one concentration (the size of the read-out at that concentration, not a potency): 43.1%
Compound 3: middle estimate off by 21.1 percentage points, on the low side; measured number outside the range, above it.
By their numbers in this assay, from the lowest: compounds 1 and 2 (each within the scatter of the next); then compound 3.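

In this assay, going by these compounds alone, the place on the six-membered aromatic ring of carbon only, para to a large group, gives the first readable single change: trifluoromethyl in place of nitro comes with a number 19.5 percentage points higher from compound 1 to compound 3 (beyond the scatter) on the shared core. The read-out therefore responds to the group at this place, and nitro is not needed there for inhibition at the one concentration tested, although this rests on a single pair and sets no trend. No measured property of either group accompanies the result, so the data give no reason for the step.

Going by these compounds, it remains open how other groups at this place would compare, such as a chlorine atom, a methoxy group, an amine or a carboxylic acid, and whether the rise follows from losing nitro or from gaining trifluoromethyl, which a compound with plain hydrogen at this place could help separate. Compound 2 differs from both other compounds in several places and adds nothing on this question, while a single-concentration read-out leaves the potency of compound 3 undefined.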